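Chloro on the phenyl ring of compound 3

A few compounds are considered here, and "the series" means these few. Any claim that something is new, unique, unknown or untested is made for them only; others in the source may bear on it.

- compound 1 `Nc1ccccc1NC(=O)c1ccc(CNCc2nc(-c3ccc(F)cc3)no2)cc1` gives 3510 nM
- compound 2 `Nc1ccccc1NC(=O)c1ccc(CNCc2nc(-c3cccs3)no2)cc1` gives 27200 nM
- compound 3 `O=C(NO)c1ccc(CNCc2nc(-c3ccccc3)no2)cc1` gives 29300 nM

In a functional assay on HCT-116 cells (Homo sapiens) for inhibition, read by MTT assay, with a stated time of 72 h (on this read-out higher numbers stand for weaker inhibition and lower numbers for stronger inhibition), compound 3 gives 29300 nM and is level, within the scatter, with compound 2 at 27200 nM while compound 1 at 3510 nM shows a lower number than either.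

The next compound is compound 4 `O=C(NO)c1ccc(CNCc2nc(-c3ccc(Cl)cc3)no2)cc1` with the change chloro in place of hydrogen on an aromatic carbon in which phenyl becomes 4-chlorophenyl.

Among the measured compounds shown here, only one measured step touches this aryl group: a 7.7-fold higher number from compound 1 to compound 2 (0.89 log units; beyond the scatter) with thiophen-2-yl in place of 4-fluorophenyl on an aromatic carbon. That step is modest and sits on a different remainder of the structure. The series also holds no unsubstituted phenyl partner for compound 1, so it guides the direction only loosely. A somewhat lower number in this assay is expected, smaller than that measured step, and a result within the scatter remains possible. An estimated step of a 2.1-fold lower number from compound 3 to compound 4 (0.32 log units; beyond the scatter) is expected on this basis. For compound 4 the estimated value is 14000 nM with an expected range from 4000 nM to 40000 nM as the working bounds.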

Compound 4, half-maximal inhibitory concentration: 30200 nM
Beside the measured number, compound 4's estimate is 2.2-fold (0.33 log units) below it, and the stated range covers the measured number.
By their numbers in this assay, from the lowest: compound 1; then compounds 2, 3 and 4 (each within the scatter of the next).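

In this assay, chloro in place of hydrogen on the aromatic carbon para to a large group gives a 1.0-fold higher number from compound 3 to compound 4 (0.01 log units; within the scatter), so phenyl and 4-chlorophenyl cannot be told apart on the remainder shared by compound 3 and compound 4. Among the compounds shown here, this is the first step read at this position on that remainder; the only earlier change to this aryl group, a 7.7-fold higher number from compound 1 to compound 2 (0.89 log units; beyond the scatter), lay on a different remainder and went beyond the scatter. No accompanying measurement bears on the reason for this level result.

As far as these compounds go, whether methoxy, trifluoromethyl or an amine at this same place would move the number on this remainder stays open. Also open is whether phenyl and 4-chlorophenyl would read level on the remainder of compound 1, where no such pair is shown.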